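Working notes: ethoxy to propoxy on the shared core

The compounds below may be only part of what the source reports. "The series", "measured", "known", "first", "only" and "open" are said of these compounds alone.

Compound 1 `C=Cc1cccc(-c2[nH]c3cc(OC)ccc3c(=O)c2C(=O)OCC)c1`: > 22000 nM (a limit)
Compound 2 `CCOC(=O)c1c(-c2cccc(OC)c2)[nH]c2cc(OC)ccc2c1=O`: > 22000 nM (a limit)
Compound 3 `CCOC(=O)c1c(-c2cccc(OCC)c2)[nH]c2cc(OC)ccc2c1=O`: > 22000 nM (a limit)

In an ADME assay on HEK293 cells (Homo sapiens) for cytotoxicity, read by luminescence, with a stated time of 72 h (a lower number here means that less compound is needed, a higher number that more compound is needed for the effect), compound 3 gives > 22000 nM, which is a limit and not a number. Within the data shown here, every value so far is of this kind: the limit of > 22000 nM in this assay, at which 3 of the 3 values shown sit.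

The next structure is compound 4 `CCCOc1cccc(-c2[nH]c3cc(OC)ccc3c(=O)c2C(=O)OCC)c1`. The change is methyl in place of hydrogen on a saturated chain carbon, two bonds along the chain from an oxygen on an aromatic ring, and cut one bond further out it reads ethoxy to propoxy.

The closest measured change is a step that the two limits leave unreadable from compound 2 to compound 3, also methyl in place of hydrogen on the same chain. Two further steps bear on it less directly: a step that the two limits leave unreadable from compound 1 to compound 2 and a step that the two limits leave unreadable from compound 1 to compound 3. None of these gives a size to carry over, so no step beyond the scatter and no direction is expected in this assay. The expected outcome is a number no higher from compound 3 to compound 4 (the limit leaves the size open). Compound 4 is estimated at 22000 nM, with an expected range of 11000 nM to 30000 nM.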

Compound 4, half-maximal effective concentration: > 22000 nM
Compound 4: no number, only a limit (the forecaster's own chance of this, stated with the estimate: 85%); the middle value sits exactly at the limit.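

In this assay compound 4 gives > 22000 nM, a limit, and no step among compound 1, compound 2, compound 3 and compound 4 can be read: the limit of > 22000 nM in this assay, at which 4 of the 4 values shown sit.

The compounds shown leave open where each half-maximal effective concentration lies and whether vinyl, methoxy, ethoxy and propoxy differ at all.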